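From 2,6-dimethylphenyl to furan-2-yl on a shared core

A few compounds are considered here, and "the series" means these few. Any claim that something is new, unique, unknown or untested is made for them only; others in the source may bear on it.

Measured so far in a functional assay on PC-3 cells (Homo sapiens) for cytotoxicity (on this read-out higher numbers stand for an effect only at larger amounts of compound and lower numbers for an effect already at smaller amounts), for two compounds:
Compound 1 `COC1=C(C)C(=O)/C(=C(O)/C=C/c2ccc(F)cc2)C(=O)C1(C)C` gives 7.2 ug/mL
Compound 2 `COC1=C(C)C(=O)/C(=C(O)/C=C/c2c(C)cccc2C)C(=O)C1(C)C` gives 17.1 ug/mL

Within the data shown here, compound 2 stands at the top of these two numbers, and its only neighbour is compound 1. The change to compound 3 `COC1=C(C)C(=O)/C(=C(O)/C=C/c2ccco2)C(=O)C1(C)C` is furan-2-yl in place of 2,6-dimethylphenyl on a double-bonded chain carbon bound to a double-bonded chain carbon and puts furan-2-yl in place of 2,6-dimethylphenyl on a double-bonded chain carbon bound to a double-bonded chain carbon. Among the measured compounds shown here, one measured step bears on this place, namely a 2.4-fold higher number from compound 1 to compound 2 (0.38 log units; beyond the scatter) and this step is modest. For the measured compounds named here, no compound carrying furan-2-yl has a value yet, so the guide is thin. With compound 2 at 17.1 ug/mL as the higher of the pair, a step of similar or smaller size toward a lower number is expected in this assay for the new compound. The expected step is a 1.9-fold lower number from compound 2 to compound 3 (0.28 log units; within the scatter) and it remains an estimate. For compound 3 the estimated value is 9 ug/mL within an expected range from 4 ug/mL to 22 ug/mL in this read-out.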

Compound 3, concentration for half-maximal effect: 20.6 ug/mL
The estimate for compound 3 lay 2.3-fold (0.36 log units) below the measured number, and the stated range covers the measured number.
By their numbers in this assay, from the lowest: compound 1; then compounds 2 and 3 (each within the scatter of the next).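

In this assay the exchange of 2,6-dimethylphenyl for furan-2-yl, on a double-bonded chain carbon bound to a double-bonded chain carbon, comes to a 1.2-fold higher number from compound 2 to compound 3 (0.08 log units; within the scatter) and so does not separate the two compounds, although a six-membered aromatic ring of carbon only gives way to a five-membered aromatic ring with 1 hetero atom and fewer heavy atoms. Furan-2-yl in place of 4-fluorophenyl gives a 2.9-fold higher number from compound 1 to compound 3 (0.46 log units; beyond the scatter) and, together with the earlier step, this leaves compound 1 apart from two quite different groups, with the lowest number of the three and both of its steps beyond the scatter. No independent measurement is at hand that would account for these numbers.

The compounds shown leave open whether the lower number of compound 1 goes with the fluorine or with the phenyl ring that carries it, a question that unsubstituted phenyl in the same place would address. They also leave open how an amine or a carboxylic acid on that ring, or a longer chain at this place, would read on the shared core.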